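The compounds below may be only part of what the source reports. "The series", "measured", "known", "first", "only" and "open" are said of these compounds alone.

Within the data shown here, compound 3 `CN(C)C/C=C/C(=O)Nc1cccc(Nc2nc(N/N=C/c3ccc(F)cc3)ncc2Cl)c1` stands at the low end of the three numbers so far in an ADME assay on HT-29 cells (Homo sapiens) for inhibition, read by MTT assay, with a stated time of 72 h (on this read-out lower numbers stand for stronger inhibition and higher numbers for weaker inhibition), giving 3300 nM, while compound 1 `C=CC(=O)Nc1cccc(Nc2nc(N/N=C(\C)c3ccc(F)cc3F)ncc2Cl)c1` gives 4360 nM and compound 2 `C=CC(=O)Nc1cccc(Nc2nc(N/N=C(\C)c3ccc(OC)cc3)ncc2Cl)c1` gives 4560 nM, all within the scatter of one another. Compound 4 `COc1cccc(/C(C)=N/Nc2ncc(Cl)c(Nc3cccc(NC(=O)/C=C/CN(C)C)c3)n2)c1` differs from compound 3 in a single place: a group of 11 heavy atoms (9 carbon, 1 nitrogen, 1 oxygen; one six-membered aromatic ring of carbon only) in place of a group of 9 heavy atoms (7 carbon, 1 nitrogen, 1 fluorine; one six-membered aromatic ring of carbon only), on a nitrogen on an aromatic ring. Among the measured compounds shown here, the only measured step that resembles this swap is a 1.0-fold higher number from compound 1 to compound 2 (0.02 log units; within the scatter), in which one aromatic ring bearing fluorine gave way to one bearing methoxy on the same kind of nitrogen without leaving the scatter. A comparable change is therefore expected to move this assay little, so the estimated step is a 1.1-fold higher number from compound 3 to compound 4 (0.03 log units; within the scatter). Compound 4 is estimated at 3500 nM, within a range from 1500 nM to 8000 nM.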

Compound 4, half-maximal inhibitory concentration: 3870 nM
Beside the measured number, compound 4's estimate is 1.1-fold (0.04 log units) below it, within the range that was stated.
By their numbers in this assay, from the lowest: compounds 3, 4, 1 and 2 (each within the scatter of the next).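

In this assay, swapping the group of 9 heavy atoms for the group of 11 heavy atoms on this nitrogen gives a 1.2-fold higher number from compound 3 to compound 4 (0.07 log units; within the scatter) and so leaves the reading unchanged within the scatter. Compounds 1 and 2 showed this only with the plain acrylamide, whereas compounds 3 and 4 show it with the dimethylamino side chain. No supporting measurement bears on this result. From the compounds shown here alone, whether an aromatic ring carrying an amine or a carboxylic acid on this nitrogen would move the number beyond the scatter stays open.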